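Solubility after replacing a halogenated benzyl with phenethyl

A few compounds are considered here, and "the series" means these few. Any claim that something is new, unique, unknown or untested is made for them only; others in the source may bear on it.

Measured compounds:
compound 1, `COc1cccc(Oc2ccc3c(NCCCNCc4cccc(OC)c4O)ccnc3c2)c1`, 14500 nM
compound 2, `COc1cccc(CNCCCNc2ccnc3cc(Cc4ccc(F)cc4Cl)ccc23)c1O`, 4200 nM

In a physicochemical assay for solubility, with a stated time of 18 h, at pH 7.4 (a lower number here means a less soluble compound, a higher number a more soluble compound), compound 1 gives 14500 nM, while compound 2 gives 4200 nM. Among the compounds with values here, compound 2 thus holds the lowest of the two numbers, and the single measured step, a 3.5-fold lower number from compound 1 to compound 2 (0.54 log units; beyond the scatter), separates it from compound 1. Compound 3, `COc1cccc(CNCCCNc2ccnc3cc(CCc4ccccc4)ccc23)c1O`, has not yet been measured in this assay. It differs from compound 2 in one place: benzyl in place of 2-chloro-4-fluorophenyl on a saturated chain carbon bound to an aromatic carbon. Within the data shown here, the only measured step changed the whole group on the shared core together with its linking atom, so it bears on this change only loosely; no measured pair isolates the loss of the two halogens or the added chain carbon. Compound 3 is therefore expected to show a small rise, a 1.5-fold higher number from compound 2 to compound 3 (0.19 log units; within the scatter), with a wide range that allows for no change beyond the scatter. The estimate for compound 3 is 6500 nM, between 2500 nM and 16000 nM.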

Compound 3, solubility: 4200 nM
Estimate against measurement, compound 3: 1.5-fold (0.19 log units) above; the measured number falls inside the stated range.
By their numbers in this assay, from the lowest: compounds 2 and 3 (each within the scatter of the next); then compound 1.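

In this assay, going from 2-chloro-4-fluorobenzyl to phenethyl gives no change at the digits printed from compound 2 to compound 3 (within the scatter), so removing the chlorine and fluorine while changing the benzyl link to phenethyl leaves no readable difference at this position. Phenethyl in place of 3-methoxyphenoxy gives a 3.5-fold lower number from compound 1 to compound 3 (0.54 log units; beyond the scatter), matching a 3.5-fold lower number from compound 1 to compound 2 (0.54 log units; beyond the scatter), so compound 1, the only one of the three carrying 3-methoxyphenoxy, stands apart from both carbon-linked compounds. Nothing in the information shown explains these numbers.

The compounds shown leave open whether the gap to compound 1 goes with the linking oxygen or with the methoxy group, and no pair here changes one without the other. They also leave open how the number would respond to an amine or a carboxylic acid in this place.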